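This account rests on a few compounds, and the source may have more. Where it says the series, first, only, none or still open, it means among the compounds named here.

In a functional assay on GTL 16 cells for antiproliferative activity against GTL 16 cell line (Homo sapiens), read by CCK-8 assay, with a stated time of 72 h (a higher number here means a weaker inhibitor, a lower number a stronger inhibitor), compound 1 `O=C(Nc1cccc(-c2oc3cc(-c4ccc(F)cc4)ccc3c(=O)c2O)c1)c1ccc(F)cc1` gives 14600 nM and compound 2 `Cc1ccccc1C(=O)Nc1cccc(-c2oc3cc(-c4ccc(F)cc4)ccc3c(=O)c2O)c1` gives 24800 nM. On these two numbers compound 2 sits alongside compound 1, since the step of a 1.7-fold higher number from compound 1 to compound 2 (0.23 log units; within the scatter) lies within the scatter. Compound 3 `COc1cc(OC)cc(C(=O)Nc2cccc(-c3oc4cc(-c5ccc(F)cc5)ccc4c(=O)c3O)c2)c1` differs from compound 2 by 3,5-dimethoxyphenyl in place of 2-methylphenyl on a carbonyl carbon. Among the measured compounds shown here, the one measured step that also exchanges the aryl group on the carbonyl carbon, a 1.7-fold higher number from compound 1 to compound 2 (0.23 log units; within the scatter), stayed within the scatter, so in this assay no step beyond the scatter is expected for compound 3. Compound 3 is estimated at 22000 nM, range 9000 nM to 55000 nM. The expected step is a 1.1-fold lower number from compound 2 to compound 3 (0.05 log units; within the scatter).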

Compound 3, half-maximal inhibitory concentration: 19600 nM
Compound 3: middle estimate off by 1.1-fold (0.05 log units), on the high side, within the range that was stated.
By their numbers in this assay, from the lowest: compounds 1, 3 and 2 (each within the scatter of the next).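

With 3,5-dimethoxyphenyl on the carbonyl carbon, this assay gives a 1.3-fold lower number from compound 2 to compound 3 (0.10 log units; within the scatter) and a 1.3-fold higher number from compound 1 to compound 3 (0.13 log units; within the scatter) as its two readings, so three differently substituted phenyl groups now sit within the scatter of one another. Adding two hydrogen-bond acceptors on this aryl group leaves the number within that scatter of both earlier compounds. No supporting measurement bears on this result.

Still open, from the compounds shown here alone, is whether a group other than substituted phenyl at this place, such as an aliphatic amine or a carboxylic acid, would move the number beyond the scatter.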